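Ring-nitrogen substituent and antiproliferative read-out

The compounds below may be only part of what the source reports. "The series", "measured", "known", "first", "only" and "open" are said of these compounds alone.

Going by the values given here, compound 2 `Nc1ccccc1NC(=O)c1ccc(CSC(=S)N2CCN(c3ncccn3)CC2)cc1` gives 67.9% in a functional assay on A-375 cells (Homo sapiens) for antiproliferative activity, read by CCK-8 assay, with a stated time of 72 h, tested at 8 uM (on this read-out lower numbers stand for a weaker effect and higher numbers for a stronger effect at the one concentration tested), the higher of the two numbers measured so far. Compound 1 `Nc1ccccc1NC(=O)c1ccc(CSC(=S)N2CCN(Cc3ccccc3)CC2)cc1` gives 29.3% in this assay. Among the compounds with values here, the one measured step, a number 38.6 percentage points higher from compound 1 to compound 2 (beyond the scatter), shows that the group on the ring nitrogen moves the read-out strongly. Compound 3 `CN1CCN(C(=S)SCc2ccc(C(=O)Nc3ccccc3N)cc2)CC1` differs from compound 2 by methyl in place of pyrimidin-2-yl on an amine nitrogen in a ring. Within the data shown here, no measured step swaps pyrimidin-2-yl for methyl, so the only bearing evidence is the step from compound 1 to compound 2, in which pyrimidin-2-yl enters and the number rises by a large amount. Because a number 38.6 percentage points higher from compound 1 to compound 2 (beyond the scatter) is large, removing pyrimidin-2-yl again is expected to give a step downward beyond the scatter, a number 27.9 percentage points lower from compound 2 to compound 3 (beyond the scatter). Compound 3 is therefore estimated at 40% in this assay, with a range from 20% to 60%.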

Compound 3, a percentage reported as inhibition, at one concentration (the size of the read-out at that concentration, not a potency): 91.6%
The estimate for compound 3 lay 51.6 percentage points below the measured number, and the stated range ends below it.
By their numbers in this assay, from the lowest: compound 1; then compound 2; then compound 3.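

Notes on the group on the amine nitrogen in a ring: in this assay a ring on this nitrogen is not needed for a high read-out, as methyl, which has no ring, gives a number 23.7 percentage points higher from compound 2 to compound 3 (beyond the scatter) and so outdoes pyrimidin-2-yl. The same change measured against benzyl gives a number 62.3 percentage points higher from compound 1 to compound 3 (beyond the scatter) and places compound 3 highest of the three, so both groups carrying an aromatic ring stand under methyl in this small set. Nothing measured here explains why the read-out follows this group.

From the compounds shown here alone, it remains open whether the high read-out is particular to methyl or is shared by hydrogen, an ethyl or longer chain, or a chain ending in an amine or a carboxylic acid. The three compounds also leave open whether this order would hold at other concentrations.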